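Halogen exchange on the ester: compound 2 to compound 3

The source may report more compounds than this note shows. Statements on the series, on what has been measured and on what is new or still open speak of the compounds shown alone.

Measured so far:
- compound 1 `O=C(O)c1cnc(-c2ccccc2Cl)[nH]c1=O` gives 5 mg/kg in a functional assay on the whole organism (strain Sprague-Dawley) for inhibition, with Rattus norvegicus as the target, with a stated time of 10 min; a higher number here means that more compound is needed for the effect, a lower number that less compound is needed
- compound 2 `CCOC(=O)c1cnc(-c2ccccc2F)[nH]c1=O` has the limit > 10 mg/kg in this assay and no number

Compound 2 therefore stands at a limit of the assay (the limit of > 10 mg/kg in this assay, at which 1 of the 2 values shown sits) and not at a measured number. Compound 3 `CCOC(=O)c1cnc(-c2ccccc2Cl)[nH]c1=O` is the next compound to be tested. It departs from compound 2 in one place (chloro in place of fluoro on an aromatic carbon) with chloro in place of fluoro on an aromatic carbon, ortho to a large group. Among the compounds with values here, no pair of measured compounds isolates this exchange, so the expectation rests on the structural change alone. In this assay the expected step is none beyond the scatter, in either direction (a step that the limit leaves unreadable from compound 2 to compound 3) and compound 3 is expected to stay close to compound 2. The estimate for compound 3 is an expected 12 mg/kg with an estimated range (5 mg/kg to 30 mg/kg).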

Compound 3, dose for 50% inhibition: 5 mg/kg
For compound 3 the middle estimate is 2.4-fold (0.38 log units) above the measured one; low and high end bracket the measured number.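

In this assay chloro in place of fluoro on an aromatic carbon, ortho to a large group, gives an at least 2.0-fold lower number from compound 2 to compound 3 (0.30 log units; that floor lies within the scatter) and so can be read only as a floor on the step. With chloro held in place, the ethyl group on the ester gives no change at the digits printed from compound 1 to compound 3 (within the scatter) and does not separate the ethyl ester from the free carboxylic acid in this read-out. Compound 2 stands at a limit and not at a number: the limit of > 10 mg/kg in this assay, at which 1 of the 3 values shown sits.

Going by these compounds, the true size of the halogen step stays open, as does whether fluoro and chloro differ beyond the scatter. Also open, on these data alone, is how a bromo or methoxy group at this place, or a longer chain such as propyl on the ester oxygen, would read in this assay on the shared core.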